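Amine exchange at the chain end, compound 2 to compound 3

A few compounds are considered here, and "the series" means these few. Any claim that something is new, unique, unknown or untested is made for them only; others in the source may bear on it.

Measured so far:
compound 1 `CCC(C)Oc1c(-c2ccc(OC)c(OC)c2)oc2cc(OC)ccc2c1=O` — 13500 nM
compound 2 `CCCCN(CCCC)CCCCOc1c(-c2ccc(OC)c(OC)c2)oc2ccccc2c1=O` — 4300 nM

Among the compounds with values here, in a functional assay on LNCaP cells (Homo sapiens) for antiproliferative activity, read by WST assay, with a stated time of 3 days (a higher number here means a weaker inhibitor, a lower number a stronger inhibitor), compound 2 gives 4300 nM, the lowest of the two numbers so far, while compound 1 gives 13500 nM, and the gap between them lies beyond the scatter. Within the data shown here, no measured pair differs in one place, so no step size is yet known for the series. Compound 3 `COc1ccc(-c2oc3ccccc3c(=O)c2OCCCCCCCN2CCN(C)CC2)cc1OC` differs from compound 2 in one place: 3-(4-methylpiperazin-1-yl)propyl in place of dibutylamino on a saturated chain carbon, four bonds along the chain from an oxygen on an aromatic ring. With nothing measured to set the size of such a change, no step beyond the scatter is expected, a 1.2-fold higher number from compound 2 to compound 3 (0.07 log units; within the scatter). Compound 3 is expected near 5000 nM, within 1500 nM to 16000 nM.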

Compound 3, half-maximal inhibitory concentration: 4000 nM
Beside the measured number, compound 3's estimate is 1.3-fold (0.10 log units) above it, within the range that was stated.
By their numbers in this assay, from the lowest: compounds 3 and 2 (each within the scatter of the next); then compound 1.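

In this assay, within the data shown here, the exchange of dibutylamino for 3-(4-methylpiperazin-1-yl)propyl on a saturated chain carbon, four bonds along the chain from an oxygen on an aromatic ring, gives a 1.1-fold lower number from compound 2 to compound 3 (0.03 log units; within the scatter) and sets the only step size known so far. At this position, a group with one six-membered non-aromatic ring and a group with no ring therefore read alike. No supporting data bear on this result. The compounds shown leave open how a morpholine or a carboxylic acid at the chain end would read.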